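This account rests on a few compounds, and the source may have more. Where it says the series, first, only, none or still open, it means among the compounds named here.

Compound 1 `CC(C)(C)c1ccc(C(=O)OCc2cn(-c3ccnc4cc(Cl)ccc34)nn2)cc1` carries a tert-butyl group on the shared core. In an ADME assay on HepG2 cells (Homo sapiens) for cytotoxicity, read by MTT assay, with a stated time of 24 h (on this read-out higher numbers stand for lower toxicity in this test and lower numbers for higher toxicity in this test), compound 1 returns only a limit, > 2380000 nM, and no number. This places compound 1 at the limit of > 2380000 nM in this assay, at which 1 of the 2 values shown sits. Compound 2 `COc1c(F)c(F)cc(C(=O)OCc2cn(-c3ccnc4cc(Cl)ccc34)nn2)c1F` likewise returns only a limit in this assay, > 2230000 nM. Compound 2 sits at the limit of > 2230000 nM in this assay, at which 1 of the 2 values shown sits. With both values at a limit, compound 1 cannot be ordered against compound 2. Compound 3 `COc1ccc(C(=O)OCc2cn(-c3ccnc4cc(Cl)ccc34)nn2)cc1` differs from compound 1 by methoxy in place of tert-butyl on an aromatic carbon. Among the compounds with values here, no measured step is available. The expected step of a number no higher from compound 1 to compound 3 (the limit leaves the size open) is none beyond the scatter in this assay. Compound 3 is expected to give 2380000 nM, within 1200000 nM to 4800000 nM, most likely again only as a limit.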

Compound 3, half-maximal cytotoxic concentration: 303000 nM
Estimate against measurement, compound 3: 7.9-fold (0.90 log units) above; measured number below the stated range.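

Methoxy in place of tert-butyl on this aromatic carbon gives an at least 7.8-fold lower number from compound 1 to compound 3 (0.89 log units; beyond the scatter) in this assay, so this position can move the read-out towards higher toxicity in this test. Within the data shown here, compound 3 also gives the first value in the set that is not a limit. The full size of the step stays open, as compound 1 has only a limit: the limit of > 2380000 nM in this assay, at which 1 of the 3 values shown sits.

One change cannot separate the loss of tert-butyl from the entry of methoxy. On these data alone, how an amine, a carboxylic acid or a longer chain would read at this position remains open.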